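A few compounds are considered here, and "the series" means these few. Any claim that something is new, unique, unknown or untested is made for them only; others in the source may bear on it.

Measured so far in an assay on B16-F10 cells for inhibition of Monoglyceride lipase (Mus musculus), read by fluorescence, with stated times of 60 min, 2.5 min and 2 h; a lower number here means a stronger inhibitor, a higher number a weaker inhibitor:
compound 1 `O=C(Nc1cccc(-c2ccccc2)c1)OCc1ccccc1` gives 16500 nM
compound 2 `O=C(Nc1cccc(-c2ccccc2)c1)OCCc1ccccc1` gives 17100 nM

Compound 1 has the lowest of the two numbers in this assay, and compound 2 sits closest to it; the step of a 1.0-fold higher number from compound 1 to compound 2 (0.02 log units; within the scatter) falls within the scatter, so the two compounds cannot be told apart. That step swapped the group on the saturated chain carbon bound to the oxygen beside the carbonyl, leaving the rest of the core untouched.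

Compound 3 `O=C(Nc1cccc(-c2ccc(C(F)(F)F)cc2)c1)OCc1ccccc1` is not yet measured. It differs from compound 1 as follows: trifluoromethyl in place of hydrogen on an aromatic carbon. For the measured compounds named here, this alteration sits on the aromatic ring of the core, a part of the structure that neither measured step touched, so the single known step gives no direct guidance on its effect. Without a comparable change to lean on, the expectation is no step beyond the scatter, with a step of a 1.1-fold lower number from compound 1 to compound 3 (0.04 log units; within the scatter) expected. Compound 3 is therefore estimated at 15000 nM, within a range of 5000 nM to 45000 nM.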

Compound 3, half-maximal inhibitory concentration: 9410 nM
For compound 3 the middle estimate is 1.6-fold (0.20 log units) above the measured one; the measured number falls inside the stated range.
By their numbers in this assay, from the lowest: compounds 3, 1 and 2 (each within the scatter of the next).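

In this assay, trifluoromethyl in place of hydrogen on an aromatic carbon gives a 1.8-fold lower number from compound 1 to compound 3 (0.24 log units; within the scatter) and so leaves compound 1 and compound 3 impossible to tell apart. The earlier step changed only the chain on the oxygen side of the carbonyl, whereas this one shows that four added heavy atoms on the aromatic ring, para to a large group, produce no step beyond the scatter. Nothing shown here gives a measured reason for this result.

Going by these compounds, whether an amine or a carboxylic acid at this same place would give a step beyond the scatter remains open. On these data alone, it is also open whether trifluoromethyl would leave the number just as unresolved on compound 2, with its different chain.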